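The compounds below may be only part of what the source reports. "The series", "measured", "known", "first", "only" and "open" are said of these compounds alone.

Measured so far:
Compound 1, `COc1ccc(C2N=C(SCc3ccccc3Cl)NC(C)=C2C(=O)Nc2ccc(F)cc2)cc1OC`, gives 30.3% in a functional assay on the whole organism (artery, strain albino) with Rattus norvegicus as the target, with a stated time of 600 min, at a dose of 10 mg/kg by the oral route; a higher number here means more inhibition at the dose given (going by the name of the read-out), a lower number less inhibition.
Compound 2, `COc1ccc(C2N=C(SCc3cccc(Cl)c3)NC(C)=C2C(=O)Nc2ccc(F)cc2)cc1OC`, gives 17.4% in this assay.
Compound 3, `CC1=C(C(=O)Nc2ccc(Br)cc2)C(c2ccc(Cl)cc2Cl)N=C(SCc2ccccc2Cl)N1`, gives 24.6% in this assay.

Compound 4, `CC1=C(C(=O)Nc2ccc(Br)cc2)C(c2ccc(Cl)cc2Cl)N=C(SCc2cccc(Cl)c2)N1`, has not yet been measured in this assay. It differs from compound 3 by one change: 3-chlorophenyl in place of 2-chlorophenyl on a saturated chain carbon bound to a sulfur. The same change, made on the core of compound 1, turns compound 1 into compound 2: 3-chlorophenyl in place of 2-chlorophenyl on a saturated chain carbon bound to a sulfur, and in this assay it gave a number 12.9 percentage points lower from compound 1 to compound 2 (beyond the scatter). The place of the change is worded identically in both pairs, so it is the same change on two cores. How the core of compound 3 differs from the core of compound 1 is not broken down here; the two values of compound 1 and compound 3 lie within the scatter of each other.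

Going by the values given here, with only one prior example of this change, the expectation rests on that single step. For compound 4 the expected step is a number 11.6 percentage points lower from compound 3 to compound 4 (beyond the scatter), because compound 1 to compound 2 showed a number 12.9 percentage points lower from compound 1 to compound 2 (beyond the scatter). Compound 4 is therefore estimated at 13%, expected to fall between 3% and 25%.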

Compound 4, a percentage reported as inhibition, in the whole organism at one dose (the size of the read-out at that dose, not a potency): 15.4%
Compound 4: middle estimate off by 2.4 percentage points, on the low side; the measured number falls inside the stated range.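

In this assay, 3-chlorophenyl in place of 2-chlorophenyl on a saturated chain carbon bound to a sulfur gives a number 9.2 percentage points lower from compound 3 to compound 4 (within the scatter), so on this core alone the step cannot be told apart from the usual spread of repeated measurements. Set beside the earlier step on the core of compound 1, it does not differ from it: the same change on two cores in this assay, a number 12.9 percentage points lower (beyond the scatter) from compound 1 to compound 2 and a number 9.2 percentage points lower (within the scatter) from compound 3 to compound 4, 3.7 percentage points apart, within the scatter of two such steps As far as these two pairs go, the change carries over from one core to the other in this series, but two pairs make no rule for any further core, and they do not show why the number falls where it does.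

All the compounds shown carry a chlorobenzyl group on the sulfur, so it remains open what a plain benzyl group or a longer chain would give at that place. On these data alone, it is equally open whether the change would carry over to a core with a carboxylic acid or an amine in place of the amide.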